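Methyl on the pendant phenyl in a second core

A few compounds are considered here, and "the series" means these few. Any claim that something is new, unique, unknown or untested is made for them only; others in the source may bear on it.

Measured so far:
compound 1, `ClC1=C(c2nnc(-c3ccccc3)o2)CCCc2ccccc21`, 1970 nM
compound 2, `Cc1ccc(-c2nnc(C3=C(Cl)c4ccccc4CCC3)o2)cc1`, 1400 nM
compound 3, `Cc1cc2c(cc1C)C(Cl)=C(c1nnc(-c3ccccc3)o1)CCC2`, 2760 nM

In a functional assay on MDA-MB-231 cells (Homo sapiens) for antiproliferative activity, read by sulforhodamine B assay, with a stated time of 48 h (on this read-out lower numbers stand for stronger inhibition of growth and higher numbers for weaker inhibition of growth), compound 1 gives 1970 nM and compound 2 gives 1400 nM. The two differ by methyl in place of hydrogen on an aromatic carbon, and the measured step, a 1.4-fold lower number from compound 1 to compound 2 (0.15 log units; within the scatter), is one that repeated testing could produce on its own.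

Compound 3 carries a different core; how its core differs from that of compound 1 is not broken down here. Its value in this assay and the values of compound 1 and compound 2 all sit close together.

Compound 4, `Cc1ccc(-c2nnc(C3=C(Cl)c4cc(C)c(C)cc4CCC3)o2)cc1`, is not yet measured. It arises from compound 3 by methyl in place of hydrogen on an aromatic carbon, the same change that turns compound 1 into compound 2, at the same kind of place. Among the compounds with values here, compound 4 is expected to show a 1.4-fold lower number from compound 3 to compound 4 (0.14 log units; within the scatter), resting on the single earlier step of a 1.4-fold lower number from compound 1 to compound 2 (0.15 log units; within the scatter), with the change now made on a different core. For compound 4 the estimated result in this assay is 2000 nM, between 900 nM and 4500 nM.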

Compound 4, concentration for 50% growth inhibition: 1760 nM
The estimate for compound 4 lay 1.1-fold (0.06 log units) above the measured number; low and high end bracket the measured number.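

In this assay, going from phenyl to 4-methylphenyl on the core of compound 3 gives a 1.6-fold lower number from compound 3 to compound 4 (0.20 log units; within the scatter), and set beside the same change on the core of compound 1, the two steps cannot be told apart: the same change on two cores in this assay, a 1.4-fold lower number (0.15 log units; within the scatter) from compound 1 to compound 2 and a 1.6-fold lower number (0.20 log units; within the scatter) from compound 3 to compound 4, 1.1-fold (0.05 log units) apart, within the scatter of two such steps So on these two cores the change behaves alike, and a step measured on one core was a fair guide to the step on the other. This does not show that the methyl itself affects growth inhibition. Each step alone lies within the scatter, and agreement between two such small steps says little about any further core.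

Going by these compounds, what remains open is whether a different group in that place on the pendant phenyl, such as a chlorine, a methoxy, an amine or a carboxylic acid, would give a step large enough to stand clear of the scatter. A longer chain there is equally untested by these compounds, and so is whether any such step would carry from one core to the other as the methyl step does.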